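The compounds below may be only part of what the source reports. "The series", "measured", "known", "first", "only" and "open" are said of these compounds alone.

In a functional assay on L1210 cells (Mus musculus) for inhibition (on this read-out lower numbers stand for an effect already at smaller amounts and higher numbers for an effect only at larger amounts of compound), compound 1 `[N-]=[N+]=N[C@H]1C[C@H](n2cc(F)c(N)nc2=O)O[C@@H]1CO` gives 25 uM, compound 2 `[N-]=[N+]=N[C@H]1C[C@H](n2cc(C(F)(F)F)c(=O)[nH]c2=O)O[C@@H]1CO` gives 400 uM and compound 3 `N[C@@H]1C[C@H](n2cc(I)c(=O)[nH]c2=O)O[C@@H]1CO` gives 400 uM. Compound 2 thus stands level with compound 3, the two sharing the highest number of the three, well above compound 1. No two of these compounds differ in one place only, so no measured step guides the next change. Compound 4 `[N-]=[N+]=N[C@H]1C[C@H](n2cc(F)c(=O)[nH]c2=O)O[C@@H]1CO` carries fluoro in place of trifluoromethyl on an aromatic carbon. Although it differs from compound 4 elsewhere, compound 1 also bears fluoro, and compound 1 at 25 uM points towards a lower number. The expected change is a downward one beyond the scatter, an estimated 6.7-fold lower number from compound 2 to compound 4 (0.82 log units; beyond the scatter). For compound 4 the estimated value is 60 uM, within an expected range of 10 uM to 350 uM.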

Compound 4, concentration for half-maximal effect: 20 uM
Compound 4: middle estimate off by 3.0-fold (0.48 log units), on the high side; low and high end bracket the measured number.
By their numbers in this assay, from the lowest: compounds 4 and 1 (each within the scatter of the next); then compounds 2 and 3 (each within the scatter of the next).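

In this assay, this position on the aromatic carbon now has its first measured step: with the rest of the structure unchanged, fluoro in place of trifluoromethyl gives a 20-fold lower number from compound 2 to compound 4 (1.30 log units; beyond the scatter) and so shows that the read-out depends strongly on which of these two groups sits there. The earlier compounds shown here could not show this, since none of them differed in one place only. The compounds shown leave open how a methyl, a chloro or a nitrile on this carbon would read. No measurement given here explains the size of this step.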